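A few compounds are considered here, and "the series" means these few. Any claim that something is new, unique, unknown or untested is made for them only; others in the source may bear on it.

Four thiosemicarbazones built on one shared core are compared here. Compound 1 `CC1=CC[C@H](C(C)(C)NC(=S)N/N=C/c2ccccc2)CC1` and compound 2 `COc1ccc(/C=N/NC(=S)NC(C)(C)[C@H]2CC=C(C)CC2)cc1` differ by methoxy in place of hydrogen on an aromatic carbon. In a functional assay on HT-29 cells (Homo sapiens) for inhibition, read by sulforhodamine B assay, with a stated time of 48 h (on this read-out lower numbers stand for stronger inhibition of growth and higher numbers for weaker inhibition of growth), compound 1 gives 22200 nM. In this assay compound 2 gives 33600 nM. Taken together these two values show a 1.5-fold higher number from compound 1 to compound 2 (0.18 log units; within the scatter). Compound 3 `CC1=CC[C@H](C(C)(C)NC(=S)N/N=C(\C)c2ccccc2)CC1` rests on a core that differs from that of compound 1; the difference between the two cores is not broken down here. In this assay compound 3 reaches only the limit of the measurement, > 100000 nM. That reading sits at the limit of > 100000 nM in this assay, at which 1 of the 3 values shown sits. For the measured compounds named here, compound 4 `COc1ccc(/C(C)=N/NC(=S)NC(C)(C)[C@H]2CC=C(C)CC2)cc1` has not yet been measured in this assay; it differs from compound 3 by methoxy in place of hydrogen on an aromatic carbon, the same change as the one between compound 1 and compound 2. The step that the limit leaves unreadable from compound 3 to compound 4 is expected to be small because a 1.5-fold higher number from compound 1 to compound 2 (0.18 log units; within the scatter) stayed within the scatter. Compound 4 is therefore estimated at 150000 nM, most likely again reported only as a limit. The range expected for compound 4 runs from 60000 nM to 400000 nM.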

Compound 4, concentration for total growth inhibition: > 100000 nM
Compound 4 gave a limit, no number (the forecaster's own chance of this, stated with the estimate: 75%); the middle value is on the limit's open side.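

In this assay, compound 3 and compound 4 both give only a limit, not a number, so no step between them can be read: the limit of > 100000 nM in this assay, at which 2 of the 4 values shown sit.

Still open, as far as these compounds go, is whether methoxy in place of hydrogen stays within the scatter on this core, as it does between compound 1 and compound 2.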